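From 4-hydroxycyclohexyl to (4-hydroxycyclohexyl)methyl

The source may report more compounds than this note shows. Statements on the series, on what has been measured and on what is new or still open speak of the compounds shown alone.

Measured so far in an ADME assay on S9 fraction from liver (Rattus norvegicus) for metabolic stability, with a stated time of 1 h (on this read-out higher numbers stand for a more stable compound and lower numbers for a less stable compound), are three compounds:
- compound 1 `N#Cc1cnc(NCc2cnccc2C(F)(F)F)cc1N[C@H]1C[C@@H](O)C1` gives 70% of remaining compound
- compound 2 `N#Cc1cnc(NCc2cnccc2C(F)(F)F)cc1N[C@H]1C[C@H](O)C1` gives 82% of remaining compound
- compound 3 `N#Cc1cnc(NCc2cnccc2C(F)(F)F)cc1N[C@H]1CC[C@H](O)CC1` gives 25% of remaining compound

Compound 3 has the lowest of these numbers, clearly apart from both others. Compound 4 `N#Cc1cnc(NCc2cnccc2C(F)(F)F)cc1NC[C@H]1CC[C@H](O)CC1` has not been measured. It carries (4-hydroxycyclohexyl)methyl in place of 4-hydroxycyclohexyl on a nitrogen on an aromatic ring.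

The closest guides are the two steps that put 4-hydroxycyclohexyl in place of 3-hydroxycyclobutyl at that same nitrogen (a number 45 percentage points lower from compound 1 to compound 3 (beyond the scatter) and a number 57 percentage points lower from compound 2 to compound 3 (beyond the scatter)). Both were large and downward. The remaining step (a number 12 percentage points higher from compound 1 to compound 2 (beyond the scatter)) was modest and bears less, given the fact that compounds 1 and 2 differ only in the configuration as drawn in that pair.

The new change again makes the group larger, so a further fall seems more likely than a rise. Going by the values given here, still, compound 3 at 25% has little room left, and no measured step tests this exact change. For compound 4 the estimated step is small and downward (a number 7 percentage points lower from compound 3 to compound 4 (within the scatter)), probably not beyond the scatter. Compound 4 is expected at about 18% (range 5% to 40%).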

Compound 4, percent of the compound remaining: 6%
For compound 4 the middle estimate is 12 percentage points above the measured one, within the range that was stated.
By their numbers in this assay, from the lowest: compound 4; then compound 3; then compound 1; then compound 2.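

Putting (4-hydroxycyclohexyl)methyl in place of 4-hydroxycyclohexyl on the nitrogen adds one carbon and keeps the six-membered ring and its single hydrogen-bond donor, yet in this assay this gives a number 19 percentage points lower from compound 3 to compound 4 (beyond the scatter), so this position still responds to a small enlargement even when the starting number is already low. Going by these compounds alone, measured against the 3-hydroxycyclobutyl group, the same group gives a number 64 percentage points lower from compound 1 to compound 4 (beyond the scatter) and a number 76 percentage points lower from compound 2 to compound 4 (beyond the scatter), and across these four compounds the number falls as the group on this nitrogen gains heavy atoms, with no compound going against that order, although compounds 1 and 2 share the same atoms and so cannot test it between themselves. Nothing at hand bears on why one added carbon has this effect.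

On these data alone, it remains open whether a 3-hydroxycyclopentyl group would fall between the cyclobutyl and cyclohexyl compounds, and whether an open chain such as 3-hydroxypropyl would follow the same order. Also open, as far as these compounds go, is how an amine or a carboxylic acid in place of the hydroxyl on the cyclohexyl ring would read in this assay.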